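A few compounds are considered here, and "the series" means these few. Any claim that something is new, unique, unknown or untested is made for them only; others in the source may bear on it.

In a functional assay on HCT-116 cells (Homo sapiens) for antiproliferative activity, read by MTT assay, with a stated time of 72 h (on this read-out higher numbers stand for weaker inhibition and lower numbers for stronger inhibition), compound 1 (`C#Cc1cccc(NC(=O)CCc2cccc3c2B(O)OC3)c1`) gives 3600 nM, compound 2 (`COc1ccc(-c2cccc(NC(=O)CCc3cccc4c3B(O)OC4)c2)cc1`) gives 160 nM and compound 3 (`O=C(CCc1cccc2c1B(O)OC2)Nc1cccc(-c2cccc(OC(F)(F)F)c2)c1`) gives 310 nM. Compound 3 thus stands within the scatter of compound 2 and well under compound 1. Compound 4 (`N#Cc1cccc(-c2cccc(NC(=O)CCc3cccc4c3B(O)OC4)c2)c1`) departs from compound 3 in one place: cyano in place of trifluoromethoxy on an aromatic carbon. In words, this is cyano in place of trifluoromethoxy on an aromatic carbon.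

Among the compounds with values here, only one measured step bears on this change, and only indirectly. That step is a 23-fold lower number from compound 1 to compound 2 (1.35 log units; beyond the scatter), a large one, with 4-methoxyphenyl in place of ethynyl on an aromatic carbon. Compound 2, compound 3 and compound 4 all carry a substituted phenyl group where compound 1 has ethynyl, so the change at hand does not repeat that step. Within the data shown here, no measurement yet shows the effect of cyano itself. The values of compound 2 and compound 3 lie within the scatter of each other, so no shift beyond the scatter is expected, and the estimated step is a 1.0-fold lower number from compound 3 to compound 4 (0.01 log units; within the scatter). For compound 4 the expected value is 300 nM, with an estimated range from 110 nM to 800 nM.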

Compound 4, half-maximal inhibitory concentration: 140 nM
The estimate for compound 4 lay 2.1-fold (0.33 log units) above the measured number; measured number inside the range.
By their numbers in this assay, from the lowest: compounds 4, 2 and 3 (each within the scatter of the next, the first and the last beyond it); then compound 1.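

In this assay, cyano in place of trifluoromethoxy on an aromatic carbon, meta to a large group, gives a 2.2-fold lower number from compound 3 to compound 4 (0.35 log units; beyond the scatter), which shows that a change of this small substituent alone can move the number beyond the scatter, if only modestly. The swap of 4-methoxyphenyl for 3-cyanophenyl, by contrast, gives a 1.1-fold lower number from compound 2 to compound 4 (0.06 log units; within the scatter), so these two groups are not told apart here. With 3-cyanophenyl in place of ethynyl there is a 26-fold lower number from compound 1 to compound 4 (1.41 log units; beyond the scatter), so a second substituted phenyl group, after the 4-methoxyphenyl of compound 2, goes with a large step from compound 1.

Nothing available gives a cause for any of these steps. Also open, as far as these compounds go, is how an amine or a carboxylic acid at this position would compare with cyano, and whether cyano would give a similar number at another place on the same ring.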